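The compounds below may be only part of what the source reports. "The series", "measured", "known", "first", "only" and "open" are said of these compounds alone.

Working notes on the sulfonamide series.

The series is built on a shared core, seen in compound 1 `CC1CCN(C2CCN(S(=O)(=O)c3cccc(N)c3)CC2)CC1`, compound 2 `Cc1cccc(S(=O)(=O)N2CCC(N3CCC(C)CC3)CC2)c1` and compound 3 `Cc1cc(S(=O)(=O)N2CCC(N3CCC(C)CC3)CC2)c(Cl)cc1Cl`; the three differ only in the substitution of the aromatic ring attached to the sulfonyl group. In a functional assay on DLD-1 cells (Homo sapiens) for antiproliferative activity, read by CellTiter-Glo, with a stated time of 72 h (on this read-out higher numbers stand for weaker inhibition and lower numbers for stronger inhibition), compound 1 gives 3400 nM, compound 2 gives 25 nM and compound 3 gives 2 nM. Going by the values given here, the one single-point step measured so far is a 140-fold lower number from compound 1 to compound 2 (2.13 log units; beyond the scatter), which shows that a small change on this ring can move the number a long way. Compound 3 stands lowest of the three, below compound 2 by a margin that is beyond the scatter and far below compound 1.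

The next compound, compound 4 `CC1CCN(C2CCN(S(=O)(=O)c3ccc(Cl)cc3Cl)CC2)CC1`, is derived from compound 3 by the change (hydrogen in place of methyl on an aromatic carbon). Among the compounds with values here, no measured step removes a methyl against hydrogen, so the step from compound 1 to compound 2 bears on it only indirectly, as a sign that this ring is sensitive to substitution. Given that the two chloro groups remain, the outcome for compound 4 is expected to be a modest rise in number, a 3.0-fold higher number from compound 3 to compound 4 (0.48 log units; beyond the scatter). Compound 4 is therefore estimated at 6 nM, with a range of 2 nM to 20 nM.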

Compound 4, half-maximal inhibitory concentration: 1 nM
Compound 4: the middle estimate sits 6.0-fold (0.78 log units) above what was measured; measured number outside the range, below it.
By their numbers in this assay, from the lowest: compounds 4 and 3 (each within the scatter of the next); then compound 2; then compound 1.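

In this assay, hydrogen in place of methyl on an aromatic carbon gives a 2.0-fold lower number from compound 3 to compound 4 (0.30 log units; within the scatter) and stays within the scatter, so at this place, ortho to a chloro group and para to a chloro group, methyl and hydrogen cannot be told apart. The low numbers of this pair therefore do not depend on the methyl, and compound 3 and compound 4 cannot be ranked against each other. The large steps appear instead where the whole aromatic group changes: 2,4-dichlorophenyl in place of 3-methylphenyl gives a 25-fold lower number from compound 2 to compound 4 (1.40 log units; beyond the scatter) and 2,4-dichlorophenyl in place of 3-aminophenyl gives a 3400-fold lower number from compound 1 to compound 4 (3.53 log units; beyond the scatter) on the same shared core. Going by these compounds alone, nothing measured so far explains any of these steps.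

Still open, as far as these compounds go, is whether a group larger than methyl at this place, such as an amine or a carboxylic acid, would keep the number in the range of compound 3 and compound 4. The compounds shown also leave open what each chloro group contributes on its own, and whether a methoxy group could stand in for either one.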